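This account rests on a few compounds, and the source may have more. Where it says the series, first, only, none or still open, it means among the compounds named here.

Compound 1 `OC[C@H]1O[C@@H](n2cnc3c(NCc4ccccc4Br)ncnc32)[C@H](O)[C@@H]1O` is the starting point. In a functional assay on G-361 cells (Homo sapiens) for antiproliferative activity, with a stated time of 72 h (on this read-out higher numbers stand for weaker inhibition and lower numbers for stronger inhibition), compound 1 reaches only a limit of the assay, > 166000 nM, so no single number stands for it. Compound 2 `OC[C@H]1O[C@@H](n2cnc3c(NCc4cccc(Br)c4)ncnc32)[C@H](O)[C@@H]1O` likewise gives only a limit in this assay, > 166000 nM. Compound 3 `COc1cc(CNc2ncnc3c2ncn3[C@@H]2O[C@H](CO)[C@@H](O)[C@H]2O)cc(OC)c1` has "not determined" (no result reported) in this assay. Among the compounds with values here, the one step between measured compounds, a step that the two limits leave unreadable from compound 1 to compound 2, cannot be read, and both limits sit together (the limit of > 166000 nM in this assay, at which 2 of the 3 values shown sit). Compound 4 `OC[C@H]1O[C@@H](n2cnc3c(NCc4cccc(O)c4O)ncnc32)[C@H](O)[C@@H]1O` differs from compound 1 by 2,3-dihydroxyphenyl in place of 2-bromophenyl on a saturated chain carbon bound to a nitrogen on an aromatic ring. Within the data shown here, no measured step bears on this change, so no direction can be drawn from the data. Compound 4 is therefore expected to stay near the limit of compound 1, a step that the limit leaves unreadable from compound 1 to compound 4, with an estimated value of 200000 nM between 40000 nM and 600000 nM.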

Compound 4, half-maximal inhibitory concentration: 16900 nM
Estimate against measurement, compound 4: 12-fold (1.07 log units) above; measured number below the stated range.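

In this assay, the position is not silent: 2,3-dihydroxyphenyl in place of a bromophenyl gives an at least 9.8-fold lower number from compound 1 to compound 4 (0.99 log units; beyond the scatter) and an at least 9.8-fold lower number from compound 2 to compound 4 (0.99 log units; beyond the scatter). Compound 4 is thus the only compound shown with a single number, so the phenyl substituents on this chain carbon can change the read-out. As far as these compounds go, how large these steps really are stays open, because compound 1 and compound 2 give only limits: the limit of > 166000 nM in this assay, at which 2 of the 4 values shown sit. Also open is whether both hydroxyl groups are needed, or whether one hydroxyl group or an amine on the phenyl ring would serve.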